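A few compounds are considered here, and "the series" means these few. Any claim that something is new, unique, unknown or untested is made for them only; others in the source may bear on it.

Values in a physicochemical assay for solubility (on this read-out higher numbers stand for higher solubility and lower numbers for lower solubility), so far:
- compound 1 (`O=C(Cn1ccnc1)N1CCC(NS(=O)(=O)c2cc(S(=O)(=O)c3ccccc3)ccc2C(F)(F)F)CC1`) gives 100000 nM
- compound 2 (`CC(=O)N1CCC[C@H]1C(=O)N1CCC(NS(=O)(=O)c2cc(S(=O)(=O)c3ccccc3)ccc2C(F)(F)F)CC1`) gives 12500 nM

Compound 2 holds the lower number of the two. Next comes compound 3 (`CC(C)C(=O)N1CCC[C@H]1C(=O)N1CCC(NS(=O)(=O)c2cc(S(=O)(=O)c3ccccc3)ccc2C(F)(F)F)CC1`), with isopropyl in place of methyl on a carbonyl carbon. For the measured compounds named here, no measured step covers this exact change. Going by the values given here, the one measured step (an 8.0-fold lower number from compound 1 to compound 2 (0.90 log units; beyond the scatter)) lies beyond the scatter, replaces a different group and bears on this change only loosely. On that single step, a smaller move toward a lower number is expected (a 2.1-fold lower number from compound 2 to compound 3 (0.32 log units; beyond the scatter)). Compound 3 is estimated at 6000 nM (expected range 2000 nM to 15000 nM).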

Compound 3, solubility: 100000 nM
Compound 3: middle estimate off by 17-fold (1.22 log units), on the low side, and the stated range ends below it.
By their numbers in this assay, from the lowest: compound 2; then compounds 1 and 3 (each within the scatter of the next).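

In this assay, for the compounds shown here, this is the first change on the carbonyl carbon whose other neighbour is the amide-type nitrogen in a ring, and isopropyl in place of methyl gives an 8.0-fold higher number from compound 2 to compound 3 (0.90 log units; beyond the scatter), so the number at this position moves with a small change of group. With no change at the digits printed from compound 1 to compound 3 (within the scatter), the drop seen with 1-acetylpyrrolidin-2-yl does not carry over to 1-(isopropylcarbonyl)pyrrolidin-2-yl. Nothing on hand speaks to the reason for this step.

Going by these compounds, whether the higher number is particular to isopropyl stays open. An ethyl, a tert-butyl or a dimethylaminomethyl group on that carbonyl carbon would test this.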